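The source may report more compounds than this note shows. Statements on the series, on what has been measured and on what is new or still open speak of the compounds shown alone.

Working notes on the series. Among the measured compounds shown here, in a functional assay on A549 cells (Homo sapiens) for inhibition, read by MTT assay, with a stated time of 72 h (on this read-out lower numbers stand for stronger inhibition and higher numbers for weaker inhibition), compound 1 (`Cc1ccc(NC(=O)C2CCN(C/C=C/c3ccccc3)CC2)cc1`) gives 29600 nM and compound 2 (`COc1ccc(NC(=O)C2CCN(C/C=C/c3ccccc3)CC2)cc1`) gives 83800 nM, so compound 2 holds the higher of the two numbers so far. The next compound is compound 3 (`O=C(Nc1cccc(Cl)c1)C1CCN(C/C=C/c2ccccc2)CC1`), with 3-chlorophenyl in place of 4-methoxyphenyl on an amide-type nitrogen. For the measured compounds named here, only one measured step bears on this change: a 2.8-fold higher number from compound 1 to compound 2 (0.45 log units; beyond the scatter), a modest step that arrives at the methoxy compound. Losing the methoxy group in compound 3 therefore points the other way, although no chlorine-bearing compound has been measured yet. A step of similar modest size is expected in this assay, towards a lower number. For compound 3 the estimated value is 35000 nM, with an expected range of 12000 nM to 90000 nM. The expected change is a 2.4-fold lower number from compound 2 to compound 3 (0.38 log units; beyond the scatter).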

Compound 3, half-maximal inhibitory concentration: 19100 nM
Beside the measured number, compound 3's estimate is 1.8-fold (0.26 log units) above it; low and high end bracket the measured number.
By their numbers in this assay, from the lowest: compounds 3 and 1 (each within the scatter of the next); then compound 2.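

Replacing 4-methoxyphenyl with 3-chlorophenyl on the amide-type nitrogen gives a 4.4-fold lower number from compound 2 to compound 3 (0.64 log units; beyond the scatter) in this assay, which shows that this position responds to a change of aryl group as well as to the methyl-to-methoxy swap. Replacing 4-methylphenyl with 3-chlorophenyl gives a 1.5-fold lower number from compound 1 to compound 3 (0.19 log units; within the scatter), so these two groups are not told apart here, and among the three compounds only compound 2 stands apart by steps beyond the scatter. Nothing available explains these differences at this position.

Compound 3 changes both the substituent and its place on the ring, so the compounds shown do not separate these two changes. As far as these compounds go, how a nitrile or an amine on this ring would read remains open, as does the effect of any change elsewhere on the core.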